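This account rests on a few compounds, and the source may have more. Where it says the series, first, only, none or still open, it means among the compounds named here.

Working notes on the series. Compound 1 `N#CC1=C(N)Oc2c(N)cc3nc4ccccc4nc3c2C12C(=O)N(Cc1cnnn1-c1ccccc1Br)c1ccccc12`, compound 2 `N#CC1=C(N)Oc2c(N)cc3nc4ccccc4nc3c2C12C(=O)N(Cc1cnnn1-c1ccc([N+](=O)[O-])cc1)c1ccccc12` and compound 3 `N#CC1=C(N)Oc2c(N)cc3nc4ccccc4nc3c2C12C(=O)N(Cc1cnnn1-c1cc(Cl)ccc1Cl)c1ccccc12` share one core and differ only in the aryl group on an aromatic nitrogen. In a functional assay on MCF7 cells (Homo sapiens) for antiproliferative activity, read by MTT assay, with a stated time of 48 h (a lower number here means a stronger inhibitor, a higher number a weaker inhibitor), compound 1 gives 30700 nM and compound 3 gives 33200 nM. For compound 2 this assay reports only a limit, > 50000 nM. Compound 3 therefore sits at the higher of the two numbers, with a 1.1-fold higher number from compound 1 to compound 3 (0.03 log units; within the scatter). The steps of an at least 1.6-fold higher number from compound 1 to compound 2 (0.21 log units; that floor lies within the scatter) and an at least 1.5-fold lower number from compound 2 to compound 3 (0.17 log units; that floor lies within the scatter) both rest on the limit (the limit of > 50000 nM in this assay, at which 1 of the 3 values shown sits). Compound 4 `N#CC1=C(N)Oc2c(N)cc3nc4ccccc4nc3c2C12C(=O)N(Cc1cnnn1-c1c(Cl)cc(Cl)cc1Cl)c1ccccc12` carries 2,4,6-trichlorophenyl in place of 2,5-dichlorophenyl on an aromatic nitrogen. Within the data shown here, the one measured step bearing on such an aryl swap, a 1.1-fold higher number from compound 1 to compound 3 (0.03 log units; within the scatter), lies within the scatter, so no step beyond the scatter is expected in this assay, a 1.1-fold higher number from compound 3 to compound 4 (0.02 log units; within the scatter). Compound 4 is estimated at 35000 nM, expected between 15000 nM and 80000 nM.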

Compound 4, half-maximal inhibitory concentration: 37800 nM
Compound 4: the middle estimate sits 1.1-fold (0.03 log units) below what was measured; the measured number falls inside the stated range.
By their numbers in this assay, from the lowest: compounds 1, 3 and 4 (each within the scatter of the next). At a limit, above all of these: compound 2.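

In this assay, moving to the 2,4,6-trichlorophenyl group on the aromatic nitrogen leaves the number unchanged within the scatter (a 1.1-fold higher number from compound 3 to compound 4 (0.06 log units; within the scatter)) (a 1.2-fold higher number from compound 1 to compound 4 (0.09 log units; within the scatter)). Compounds 1, 3 and 4 now form one group across three halogenated aryl groups. Against compound 2 only a floor can be read (an at least 1.3-fold lower number from compound 2 to compound 4 (0.12 log units; that floor lies within the scatter)), and it rests on a limit: (the limit of > 50000 nM in this assay, at which 1 of the 4 values shown sits).

The compounds shown leave open whether an amine or a carboxylic acid on this aryl ring, or a longer chain in its place, would move the number beyond the scatter in this assay.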